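A few compounds are considered here, and "the series" means these few. Any claim that something is new, unique, unknown or untested is made for them only; others in the source may bear on it.

Measured compounds:
compound 1 `O=C1CC(C(F)(F)F)CN1c1cnn2c1CN(C(=O)Nc1cc(F)c(F)c(F)c1)C(C1CC1)C2`, 115000 nM in a toxicity assay on HepG2 2.2.15 cells (Homo sapiens) for cytotoxicity, read by CellTiter-Glo; a higher number here means that more compound is tolerated, a lower number that less compound is tolerated
compound 2 `C[C@H]1Cn2ncc(N3CC(c4ccccc4)CC3=O)c2CN1C(=S)Nc1cc(F)c(F)c(F)c1`, > 2000 nM in this assay

Compound 1 carries a trifluoromethyl on the saturated ring carbon of its five-membered non-aromatic ring. In this assay, for the measured compounds named here, compound 1 gives 115000 nM, the only full number in the set. Compound 2 is reported only as a limit; in this assay compound 2 gives > 2000 nM, which is a limit and not a number, as the record notes: the limit of > 2000 nM in this assay, at which 1 of the 2 values shown sits. Going by the values given here, no step between measured compounds that differ in a single place is available, so the effect of the change itself has not been measured.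

Compound 3 `O=C1CC(c2ccccc2)CN1c1cnn2c1CN(C(=O)Nc1cc(F)c(F)c(F)c1)C(C1CC1)C2` is the compound to be measured. It differs from compound 1 by phenyl in place of trifluoromethyl on a saturated ring carbon. Among the compounds with values here, with no measured step to lean on, the expectation for the step from compound 1 to compound 3 is one of a modest loss in tolerated concentration, a 1.9-fold lower number from compound 1 to compound 3 (0.28 log units; within the scatter), close to the scatter. Compound 3 is therefore expected to give about 60000 nM in this assay, within a range from 15000 nM to 150000 nM.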

Compound 3, half-maximal cytotoxic concentration: 12800 nM
Beside the measured number, compound 3's estimate is 4.7-fold (0.67 log units) above it, and the stated range ends above it.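

At the saturated ring carbon two ring bonds from the ring nitrogen, the change from trifluoromethyl to phenyl gives the first measured single-place step in this assay, a 9.0-fold lower number from compound 1 to compound 3 (0.95 log units; beyond the scatter), so this position is shown not to be indifferent to the group it carries. The step lies beyond the usual scatter, and the tolerated concentration stays measurable with either group in place. Compound 2 also carries the 2-oxo-4-phenylpyrrolidin-1-yl group but differs from compound 3 in more than one place, and its value is a limit and not a number, so it adds no second reading of this change: the limit of > 2000 nM in this assay, at which 1 of the 3 values shown sits. Nothing shown bears on why the number falls with this change.

As far as these compounds go, what a cyclohexyl ring, a pyridine ring or a methyl at this carbon would give remains open, so the step cannot yet be tied to the aromatic ring of the phenyl rather than to the exchange of groups as a whole. Also open, from the compounds shown here alone, is whether the same change would give a step of similar size on a different core.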